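The source may hold more compounds than are shown below. What is called first, only, known or untested is meant among the compounds shown, and "the series" means these compounds.

Three compounds share a skeleton in which a saturated chain carries a six-membered aromatic ring with two hetero atoms. Compound 1 `COc1cc(CC(COCc2ccccc2)COCc2ccccc2)nc(OC)n1` bears two (benzyloxy)methyl arms on that chain. Compound 2 `O=c1cc(CC(COCc2ccccc2)COCc2ccccc2)[nH]c(=O)[nH]1` differs in its core: a group of 8 heavy atoms (4 carbon, 2 nitrogen, 2 oxygen; one six-membered aromatic ring with 2 hetero atoms) in place of a group of 10 heavy atoms (6 carbon, 2 nitrogen, 2 oxygen; one six-membered aromatic ring with 2 hetero atoms), on a saturated chain carbon, three bonds along the chain from two oxygens on a saturated carbon. Compound 3 `COc1cc(CC(O)COCc2ccccc2)nc(OC)n1` keeps the core of compound 1 but is shortened: hydroxy in place of (benzyloxy)methyl on a saturated chain carbon bound to two saturated chain carbons. Compound 4 `O=c1cc(CC(O)COCc2ccccc2)[nH]c(=O)[nH]1`, not yet measured, joins the core of compound 2 to the same shortened chain: hydroxy in place of (benzyloxy)methyl on a saturated chain carbon bound to two saturated chain carbons. The place of this change is worded identically for both pairs, so it is the same change made twice.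

In a functional assay on SW-620 cells (Homo sapiens) for antiproliferative activity, read by MTT assay, with a stated time of 72 h (on this read-out lower numbers stand for stronger inhibition and higher numbers for weaker inhibition), compound 1 gives > 100000 nM, which is a limit of the assay rather than a number. Compound 2 gives > 100000 nM, also a limit. Compound 3 gives > 100000 nM, again a limit. Because every value sits at the limit of > 100000 nM in this assay, at which 3 of the 3 values shown sit, the step that the two limits leave unreadable from compound 1 to compound 2 and the step that the two limits leave unreadable from compound 1 to compound 3 cannot be given a size.

For compound 4 a step that the limit leaves unreadable from compound 2 to compound 4 is expected, resting on the step that the two limits leave unreadable from compound 1 to compound 3, which showed no measurable change. Compound 4 is therefore expected to give about 200000 nM, most probably reported once more as a limit, within a range from 50000 nM to 1000000 nM.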

Compound 4, half-maximal inhibitory concentration: > 100000 nM
Compound 4: a limit, no number (the forecaster's own chance of this, stated with the estimate: 85%); the middle value lies beyond the limit too.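

In this assay compound 4 gives > 100000 nM, which is a limit of the assay and not a number. No step among compound 1, compound 2, compound 3 and compound 4 can be given a size, because all their results sit at the same limit: the limit of > 100000 nM in this assay, at which 4 of the 4 values shown sit.

The compounds shown leave open whether changing the core, or hydroxy in place of (benzyloxy)methyl, alters activity at all.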